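This account rests on a few compounds, and the source may have more. Where it says the series, first, only, none or still open, it means among the compounds named here.

Working notes on the series. In a functional assay on HL-60 cells (Homo sapiens) for cytotoxicity, read by luminescence and CellTiter-Glo, with a stated time of 3 days (a lower number here means a stronger inhibitor, a higher number a weaker inhibitor), compound 1 `N#Cc1ccc(NC(=O)c2cc(F)ccc2O)cc1` gives 1420 nM and compound 2 `N#Cc1ccc(NC(=O)c2cc(Cc3ccccc3)ccc2O)cc1` gives 1740 nM. Within the data shown here, these are the only two measured values, and they lie within the scatter of each other, so compound 2 is not set apart from compound 1.

Compound 3 `N#Cc1ccc(NC(=O)c2ccccc2O)cc1` is the next case, with hydrogen in place of benzyl on an aromatic carbon.

Among the measured compounds shown here, one measured step bears on this change: a 1.2-fold higher number from compound 1 to compound 2 (0.09 log units; within the scatter), with benzyl in place of fluoro on an aromatic carbon. Given that step, no shift beyond the scatter is expected in this assay when benzyl leaves, although a single step is thin support. The expected step is a 1.2-fold lower number from compound 2 to compound 3 (0.06 log units; within the scatter).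

Compound 3 is estimated at 1500 nM, with an expected range of 600 nM to 3800 nM.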

Compound 3, half-maximal inhibitory concentration: 4620 nM
Beside the measured number, compound 3's estimate is 3.1-fold (0.49 log units) below it; the whole stated range lies below it.
By their numbers in this assay, from the lowest: compounds 1 and 2 (each within the scatter of the next); then compound 3.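

In this assay this position turns out not to be indifferent to what it carries: the step for hydrogen in place of benzyl is a 2.7-fold higher number from compound 2 to compound 3 (0.42 log units; beyond the scatter) and the step for hydrogen in place of fluoro is a 3.3-fold higher number from compound 1 to compound 3 (0.51 log units; beyond the scatter), which makes compound 3 the weakest of the three. Compound 1 and compound 2 alone showed no difference, and only the hydrogen case shows that either substituent on this aromatic carbon, para to the hydroxy group, goes with a lower number than none, although benzyl brings a six-membered aromatic ring of carbon only and fluoro does not.

Going by these compounds, whether a methyl, a methoxy, an amine or a carboxylic acid at this carbon would also stand apart from hydrogen remains open. Nothing available explains why hydrogen differs from both fluoro and benzyl.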